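The source may hold more compounds than are shown below. What is called first, only, known or untested is meant among the compounds shown, and "the series" means these compounds.

Measured so far in a functional assay on SK-MEL-5 cells (Homo sapiens) for inhibition, read by sulforhodamine B assay, with a stated time of 48 h, tested at 10 uM; on this read-out higher numbers stand for a weaker effect at the one concentration tested and lower numbers for a stronger effect:

compound 1, `O=C(Nc1cccc(-n2cc(-c3ccncc3)c(-c3cc(O)cc(Cl)c3)n2)c1)Nc1ccc(Cl)c(Cl)c1`, gives -53.1%
compound 2, `COc1cc(Cl)cc(-c2nn(-c3cccc(NC(=O)Nc4ccc(Cl)c(Cl)c4)c3)cc2-c2ccncc2)c1`, gives 3.51%
compound 3, `O=C(Nc1cccc(-n2cc(-c3ccncc3)c(-c3cc(O)cc(Cl)c3)n2)c1)c1cc(C(F)(F)F)cc(C(F)(F)F)c1`, gives 64.5%

Compound 1 and compound 2 share a core and differ in one place: methyl in place of hydrogen on an oxygen on an aromatic ring. On this read-out the step is a number 56.6 percentage points higher from compound 1 to compound 2 (beyond the scatter), so the methyl on the oxygen goes with a markedly weaker effect at the single concentration tested. Compound 3 stands apart from compound 1 by more than one place; the difference between the two cores is not broken down here. Compound 3 gives the highest of the three numbers, and its value lies beyond the scatter from both compound 2 and compound 1.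

Compound 4, `COc1cc(Cl)cc(-c2nn(-c3cccc(NC(=O)c4cc(C(F)(F)F)cc(C(F)(F)F)c4)c3)cc2-c2ccncc2)c1`, is not yet measured in this assay. It stands to compound 3 as compound 2 stands to compound 1: methyl in place of hydrogen on an oxygen on an aromatic ring. The same change occurs twice among the compounds shown, and its only measured instance is the step from compound 1 to compound 2.

An estimate for compound 4 rests on that one step and on the starting point of compound 3, whose value is already high at 64.5%. A step of similar direction is expected, though its size is capped by how little room the read-out leaves above compound 3: the expected step is a number 20.5 percentage points higher from compound 3 to compound 4 (beyond the scatter). Compound 4 is therefore expected to give about 85%, within a range from 60% to 105%.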

Compound 4, a percentage reported as activity, at one concentration (the size of the read-out at that concentration, not a potency): 67.3%
Compound 4: the middle estimate sits 17.7 percentage points above what was measured; measured number inside the range.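

In this assay, hydroxy to methoxy on the core of compound 3 reads as a number 2.8 percentage points higher from compound 3 to compound 4 (within the scatter), so a change that goes with a large step on the core of compound 1 gives no readable difference on this core. The step therefore does not carry over at a constant size between these two cores: the same change on two cores in this assay, a number 56.6 percentage points higher (beyond the scatter) from compound 1 to compound 2 and a number 2.8 percentage points higher (within the scatter) from compound 3 to compound 4, 53.8 percentage points apart, beyond the scatter of two such steps

This shows only that the size of the step differs between these two cores at the single concentration tested; it does not show what causes that gap, and two pairs give no rule for predicting the step on a third core.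

The compounds shown leave open which of the differences between the core of compound 1 and the core of compound 3 goes with the gap between the two steps. Also open, from the compounds shown here alone, is how an ethoxy group or an amine in place of the hydroxy, on an oxygen-free or longer-chain version of that same position on the aromatic ring, would read on either core.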